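The source may hold more compounds than are shown below. What is called first, only, known or untested is meant among the compounds shown, and "the series" means these compounds.

Measured so far:
compound 1 `COc1ccc(/C=C\C(=O)O)c(OCc2cn(-c3ccc(NC(C)=O)cc3)nn2)c1CC=C(C)C` — 22600 nM
compound 2 `COc1ccccc1-n1cc(COc2c(/C=C\C(=O)O)ccc(OC)c2CC=C(C)C)nn1` — 12200 nM

Within the data shown here, in a functional assay on COLO 205 cells (Homo sapiens) for cytotoxicity, read by MTT assay, with a stated time of 24 h (a higher number here means a weaker inhibitor, a lower number a stronger inhibitor), compound 1 gives 22600 nM and sits within the scatter of compound 2, the only other measured compound, as the step of a 1.9-fold lower number from compound 1 to compound 2 (0.27 log units; within the scatter) shows; that step is a change on the aromatic nitrogen and does not touch the acetamido group.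

Compound 3 `COc1ccc(/C=C\C(=O)O)c(OCc2cn(-c3ccc(NC(=O)c4ccccc4)cc3)nn2)c1CC=C(C)C` differs from compound 1 by phenyl in place of methyl on a carbonyl carbon, acetyl to benzoyl. Among the measured compounds shown here, no measured step bears on this position, so nothing argues for a step beyond the scatter in this assay. Compound 3 is therefore expected near compound 1, with a step of a 1.1-fold lower number from compound 1 to compound 3 (0.05 log units; within the scatter), estimated at 20000 nM (range 8000 nM to 50000 nM).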

Compound 3, half-maximal inhibitory concentration: 20300 nM
Beside the measured number, compound 3's estimate is 1.0-fold (0.01 log units) below it; the range from low to high includes it.
By their numbers in this assay, from the lowest: compounds 2, 3 and 1 (each within the scatter of the next).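

Phenyl in place of methyl on a carbonyl carbon, acetamido to benzamido, gives in this assay a 1.1-fold lower number from compound 1 to compound 3 (0.05 log units; within the scatter). Among these compounds, this is the first step read at this position, and the change from one heavy atom to six, with a six-membered aromatic ring added, stays within the scatter. Nothing at hand gives a reason for this result.

Still open, going by these compounds, is whether a longer chain, an amine or a carboxylic acid on that carbonyl carbon would give a step beyond the scatter. The compounds shown also leave open whether any change at this position separates from the scatter in this series.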